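Phenyl for methoxy: an earlier step and a new case

The source may hold more compounds than are shown below. What is called first, only, known or untested is meant among the compounds shown, and "the series" means these compounds.

Compound 1 `COc1ccc(O)c(C(=O)Nc2ccc(C#N)cc2)c1` and compound 2 `N#Cc1ccc(NC(=O)c2cc(-c3ccccc3)ccc2O)cc1` share a core; compound 3 `COc1ccc(C(=O)Nc2ccc(C#N)cc2)c(O)c1` carries the same atoms joined differently, and the difference between the two cores is not broken down here. Compound 4 `N#Cc1ccc(NC(=O)c2ccc(-c3ccccc3)cc2O)cc1` is not yet measured.

In a functional assay on KG-1 cells (Homo sapiens) for cytotoxicity, read by luminescence and CellTiter-Glo, with a stated time of 3 days (a lower number here means a stronger inhibitor, a higher number a weaker inhibitor), compound 1 gives a limit of > 10000 nM, not a number. In this assay compound 2 gives 1300 nM, and compound 3 gives 5430 nM. The change from compound 1 to compound 2 is phenyl in place of methoxy on an aromatic carbon, and it brought an at least 7.6-fold lower number from compound 1 to compound 2 (0.88 log units; beyond the scatter), a size known only as a bound because of the limit of > 10000 nM in this assay, at which 1 of the 3 values shown sits.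

The change from compound 3 to compound 4 is phenyl in place of methoxy on an aromatic carbon. It is the same kind of change, but the surroundings differ: in the first case the group stands meta to a large group and para to a hydroxy group, in the second meta to a hydroxy group and para to a large group. Compound 4 is expected to give 900 nM in this assay, between 300 nM and 3000 nM, a step of a 6.0-fold lower number from compound 3 to compound 4 (0.78 log units; beyond the scatter), resting on compound 3 at 5430 nM and the earlier step of an at least 7.6-fold lower number from compound 1 to compound 2 (0.88 log units; beyond the scatter).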

Compound 4, half-maximal inhibitory concentration: 410 nM
Compound 4: the middle estimate sits 2.2-fold (0.34 log units) above what was measured, within the range that was stated.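

In this assay, putting phenyl in place of methoxy gave a 13-fold lower number from compound 3 to compound 4 (1.12 log units; beyond the scatter), so the change lowered the number on both cores shown. Set side by side, the two steps point the same way, but their sizes cannot be ranked: the same change on two cores in this assay, an at least 7.6-fold lower number (0.88 log units; beyond the scatter) from compound 1 to compound 2 and a 13-fold lower number (1.12 log units; beyond the scatter) from compound 3 to compound 4; the limit leaves it open whether they differ. The earlier step is known only as a bound, and two cases show that the change carried over between these two cores, not that it would carry over to any other core in this series: the limit of > 10000 nM in this assay, at which 1 of the 4 values shown sits.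

The compounds shown leave open whether phenyl is special or whether another group on the same aromatic carbon, such as an amine, a carboxylic acid or a longer chain, would lower the number as far. They also leave open whether a phenyl ring bearing a further group would do better or worse, and whether the same step would appear in any other cell assay.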